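From an alkenyloxy side chain to a phenylsulfonyl group

The source may report more compounds than this note shows. Statements on the series, on what has been measured and on what is new or still open speak of the compounds shown alone.

Of the compounds shown here, three have been measured in a functional assay on A549 cells (Homo sapiens) for inhibition, read by colorimetric assay and MTT assay, with a stated time of 72 h; on this read-out higher numbers stand for weaker inhibition and lower numbers for stronger inhibition. There, compound 1 (`C=CCCCCOc1ccc(F)cc1-c1cnc(OCCC=C)n1C`) gives 61000 nM. Compound 3 (`C=CCCCCOc1ncc(-c2cccc(OC)c2OC)n1C`) gives 43000 nM. Compound 2 (`C=CCCCCOc1ccccc1-c1cnc(OCCCC=C)n1C`) gives 3000 nM, the lowest of the three numbers and beyond the scatter from both of the others.

The step followed here leads to compound 4 (`C=CCCCCOc1ccccc1-c1cnc(S(=O)(=O)c2ccccc2)n1C`), which carries phenylsulfonyl in place of (pent-4-en-1-yl)oxy on an aromatic carbon.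

For the measured compounds named here, no pair of measured compounds shows this exchange, so the expectation is only a loose one. Since compound 2 at 3000 nM already holds the lowest number of the set, and compound 3 at 43000 nM shows how much higher a number can lie with the same kind of scaffold, a move toward weaker inhibition seems the likelier outcome. The expected change is a 4.7-fold higher number from compound 2 to compound 4 (0.67 log units; beyond the scatter), beyond the scatter. For compound 4 the estimated value is 14000 nM, with an expected range from 4000 nM to 50000 nM.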

Compound 4, half-maximal inhibitory concentration: 38000 nM
The estimate for compound 4 lay 2.7-fold (0.43 log units) below the measured number, and the stated range covers the measured number.
By their numbers in this assay, from the lowest: compound 2; then compounds 4, 3 and 1 (each within the scatter of the next).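

In this assay, the aromatic carbon between two ring nitrogen atoms proved sensitive to its substituent: phenylsulfonyl in place of (pent-4-en-1-yl)oxy gave a 13-fold higher number from compound 2 to compound 4 (1.10 log units; beyond the scatter), a large step. For the compounds shown here, this is the first reading of a change at this position alone, as no earlier pair of compounds differed in one place. No measured evidence bears on why the step is this large.

The compounds shown leave open whether an amine, a methylsulfonyl group or a shorter alkoxy chain at this position would give a number closer to that of compound 2 or to that of compound 4. They also leave open whether the same exchange would produce a step of similar size on a core bearing fluorine, as compound 1 does.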